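A few compounds are considered here, and "the series" means these few. Any claim that something is new, unique, unknown or untested is made for them only; others in the source may bear on it.

Of the compounds shown here, three that share one core have been tested in a functional assay on 143B cells (Homo sapiens) for inhibition, read by CCK-8 assay, with a stated time of 72 h, tested at 1 uM; a lower number here means less inhibition, a higher number more inhibition at the concentration tested (going by the name of the read-out). Compound 1 `COc1ccccc1N1C(=O)C(C)SC1c1cccc(C(=O)NCCCCc2ccccc2)c1` gives 61%. Compound 2 `COc1ccccc1N1C(=O)CSC1c1cc(F)cc(C(=O)O)c1`, which carries a carboxylic acid instead of the amide chain, gives 0%. Compound 3 `CCN1C(=O)CSC1c1cccc(C(=O)NCCCCc2ccccc2)c1` gives 40%, which places it second highest of the three numbers: compound 1 stands higher by a gap beyond the usual scatter, and compound 2 stands lower by a gap that is also beyond the scatter.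

Compound 4 `COc1ccc(N2C(=O)CSC2c2cccc(C(=O)NCCCCc3ccccc3)c2)c(OC)c1` has not yet been measured. Compared with compound 3 it differs in one place: 2,4-dimethoxyphenyl in place of ethyl on an amide-type nitrogen in a ring. Among the measured compounds shown here, no pair of measured compounds differs in just this part of the molecule, so the size of the step has to be estimated rather than read off. The nearest guide is compound 1, whose build is closer to that of compound 4 than the build of compound 3 is; in this assay compound 1 gives 61%. On that basis compound 4 is expected to show more inhibition than compound 3, and the step from compound 3 to compound 4 is estimated as a number 17 percentage points higher from compound 3 to compound 4 (beyond the scatter), a rise beyond the scatter. The expected value for compound 4 is 57%, within a range from 38% to 76%.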

Compound 4, a percentage reported as inhibition, at one concentration (the size of the read-out at that concentration, not a potency): 53%
The estimate for compound 4 lay 4 percentage points above the measured number; the measured number falls inside the stated range.
By their numbers in this assay, from the lowest: compound 2; then compound 3; then compounds 4 and 1 (each within the scatter of the next).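

In this assay, the amide-type nitrogen in the ring now has its first direct reading, as putting 2,4-dimethoxyphenyl in place of ethyl gives a number 13 percentage points higher from compound 3 to compound 4 (beyond the scatter), a modest step. The earlier compounds shown here offered no pair differing only at this nitrogen, and this pair shows that a group with a six-membered aromatic ring and two methoxy groups can replace a small two-carbon group there without losing inhibition at the tested concentration; the number in fact rises. Nothing available here accounts for this rise, so the step records an outcome and offers no explanation.

Going by these compounds, with only ethyl and 2,4-dimethoxyphenyl to compare at this nitrogen, the step cannot be divided between the aromatic ring and its two methoxy groups, and it remains open whether a plain phenyl, a benzyl or a longer chain such as butyl would land closer to compound 3 or to compound 4. Compound 1 differs from compound 4 in more than one place, so it cannot settle that question.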